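A few compounds are considered here, and "the series" means these few. Any claim that something is new, unique, unknown or untested is made for them only; others in the source may bear on it.

Three compounds have been measured in an ADME assay on MDBK cells (Bos taurus) for cytotoxicity; on this read-out lower numbers stand for higher toxicity in this test and higher numbers for lower toxicity in this test:
compound 1, `Fc1ccc(Cn2ccc3nc(-c4ccccc4)nc-3c2)cc1`, gives > 100000 nM, a limit of this assay
compound 2, `c1ccc(-c2ccc(Cn3ccc4nc(-c5ccccc5)nc-4c3)cc2)cc1`, gives 18000 nM
compound 3, `CC(c1ccccc1)n1ccc2nc(-c3ccccc3)nc-2c1`, gives > 100000 nM, again a limit

Compound 1 therefore stands at the limit of > 100000 nM in this assay, at which 2 of the 3 values shown sit, so only a bound and not a number is known for it. Compound 4, `Clc1ccc(Cn2ccc3nc(-c4ccccc4)nc-3c2)s1`, differs from compound 1 by 5-chlorothiophen-2-yl in place of 4-fluorophenyl on a saturated chain carbon bound to an aromatic nitrogen. Going by the values given here, the only measured step, an at least 5.5-fold lower number from compound 1 to compound 2 (0.74 log units; beyond the scatter), concerns a different change and bears on this one only loosely. Because compound 1 rests at the limit of > 100000 nM in this assay, at which 2 of the 3 values shown sit, any shift beyond the scatter can only be toward a lower number. A small step is expected, an at least 1.4-fold lower number from compound 1 to compound 4 (0.15 log units; that floor lies within the scatter). Compound 4 is estimated at 70000 nM, with a range from 20000 nM to 200000 nM.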

Compound 4, half-maximal cytotoxic concentration: > 100000 nM
Compound 4: only a limit was reported; the forecaster's own chance of this, stated with the estimate: 55%; middle value at least 1.4-fold (0.15 log units) from the limit.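

No step can be read between compound 1 and compound 4, because both rest at the same limit: the limit of > 100000 nM in this assay, at which 3 of the 4 values shown sit.

On these data alone, whether 5-chlorothiophen-2-yl in place of 4-fluorophenyl changes the cytotoxicity read-out at all remains open.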